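Acetamide versus amine analogues: clearance in mouse liver microsomes

The source may hold more compounds than are shown below. What is called first, only, known or untested is meant among the compounds shown, and "the series" means these compounds.

Measured compounds:
compound 1, `CC(=O)Nc1cnc2[nH]c(=O)n([C@H]3CC[C@@H](C(C)(C)C)CC3)c(=O)c2c1`: 15 mL.min-1.g-1
compound 2, `CC(=O)Nc1cnc2[nH]c(=O)n([C@H]3CC[C@@H](C(C)C)CC3)c(=O)c2c1`: 10 mL.min-1.g-1
compound 3, `CC(C)(C)[C@H]1CC[C@H](n2c(=O)[nH]c3ncc(N)cc3c2=O)CC1`: 0.5 mL.min-1.g-1

In an ADME assay on microsomes from liver (Mus musculus, strain CD1) for metabolic stability, read by HPLC, using NADPH, with a stated time of 30 min, tested at 0.5 uM (a higher number here means faster removal of the compound, a lower number slower removal), compound 1 gives 15 mL.min-1.g-1 and compound 2 gives 10 mL.min-1.g-1. The change between them, (hydrogen in place of methyl on a saturated chain carbon bound to two saturated chain carbons and a saturated ring carbon), gave a 1.5-fold lower number from compound 1 to compound 2 (0.18 log units; within the scatter), so the two values are not separated.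

Compound 3 carries a different core from compound 1; the difference between the two cores is not broken down here. In this assay compound 3 gives 0.5 mL.min-1.g-1, the lowest of the three numbers, and its separation from both compound 1 and compound 2 is beyond the scatter.

Compound 4, `CC(C)[C@H]1CC[C@H](n2c(=O)[nH]c3ncc(N)cc3c2=O)CC1`, is not yet measured. It differs from compound 3 by hydrogen in place of methyl on a saturated chain carbon bound to two saturated chain carbons and a saturated ring carbon, the same change as that from compound 1 to compound 2. That earlier step, a 1.5-fold lower number from compound 1 to compound 2 (0.18 log units; within the scatter), was within the scatter, and nothing among the four compounds indicates that the same change on the core of compound 3 should read differently. Compound 4 is therefore expected to sit close to compound 3, with an estimated step of a 1.3-fold lower number from compound 3 to compound 4 (0.10 log units; within the scatter), resting on the earlier step of a 1.5-fold lower number from compound 1 to compound 2 (0.18 log units; within the scatter). The estimate for compound 4 in this assay is 0.4 mL.min-1.g-1, within 0.2 mL.min-1.g-1 to 1.2 mL.min-1.g-1.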

Compound 4, intrinsic clearance in microsomes: 1.9 mL.min-1.g-1
The estimate for compound 4 lay 4.8-fold (0.68 log units) below the measured number; measured number outside the range, above it.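

In this assay the change from tert-butyl to isopropyl gives a 3.8-fold higher number from compound 3 to compound 4 (0.58 log units; beyond the scatter) on the core of compound 3, so the step seen on the core of compound 1 does not carry over unchanged to this second core. The two steps lie further apart than the scatter of two such steps allows, which means that in this series the reading of this change depends on the core that carries it: the same change on two cores in this assay, a 1.5-fold lower number (0.18 log units; within the scatter) from compound 1 to compound 2 and a 3.8-fold higher number (0.58 log units; beyond the scatter) from compound 3 to compound 4, 5.7-fold (0.76 log units) apart, beyond the scatter of two such steps

This rests on one pair of compounds on each core, so it shows no general rule for other chain changes or other cores, and it does not show which feature of the two cores separates the steps or by what mechanism.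

The compounds shown leave open whether the two cores also part for other groups in place of tert-butyl, such as ethyl, cyclopropyl or a longer chain. They also leave open whether the split between the cores follows the acetamide and the amine themselves, which a sulfonamide or a urea in their place on the same scaffold could test.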